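A few compounds are considered here, and "the series" means these few. Any claim that something is new, unique, unknown or untested is made for them only; others in the source may bear on it.

In a functional assay for agonist activity at Free fatty acid receptor 1 (Homo sapiens) (a higher number here means that more compound is needed for the effect, a lower number that less compound is needed), compound 2 `O=C(O)CCc1ccc(NCc2ccc(C(F)(F)F)cc2)cc1` gives 2000 nM, the higher of the two numbers at hand. Compound 1 `O=C(O)CCc1ccc(NCc2ccc(Cl)c(Cl)c2)cc1` gives 251 nM, a lower number by a margin beyond the scatter. Compound 3 `O=C(O)CCc1ccc(NCc2ccccc2)cc1` differs from compound 2 by hydrogen in place of trifluoromethyl on an aromatic carbon, a hydrogen in place of trifluoromethyl on an aromatic carbon. Going by the values given here, no measured pair tracks this change, so the size of the step is open. Compound 3 is expected to need somewhat more compound, a step of a 2.0-fold higher number from compound 2 to compound 3 (0.30 log units; within the scatter). The estimate for compound 3 is 4000 nM, within 1500 nM to 12000 nM.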

Compound 3, half-maximal effective concentration: 7940 nM
For compound 3 the middle estimate is 2.0-fold (0.30 log units) below the measured one; low and high end bracket the measured number.
By their numbers in this assay, from the lowest: compound 1; then compound 2; then compound 3.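

Read in this assay, the change to hydrogen on this aromatic carbon, para to a large group, gives a 4.0-fold higher number from compound 2 to compound 3 (0.60 log units; beyond the scatter), a step beyond the scatter. Going by these compounds alone, this is the first measured step at this position, and it shows that here trifluoromethyl needs less compound than hydrogen does. Nothing at hand bears on the cause of this step.

On these data alone, whether this holds for other groups at this position, such as a methoxy group or an amine, remains open. So does whether the same change would give a step of similar size on a different core.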